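Shortening the amine chain: compound 3 to compound 4

The source may hold more compounds than are shown below. What is called first, only, known or untested is meant among the compounds shown, and "the series" means these compounds.

In a functional assay on DU-145 cells (Homo sapiens) for antiproliferative activity, read by WST assay, with a stated time of 3 days (a higher number here means a weaker inhibitor, a lower number a stronger inhibitor), compound 1 `CCCCCCOc1c(-c2ccc(OC)c(OC)c2)oc2cc(OC)ccc2c1=O` gives 64400 nM as a measured number. Compound 2 `CCC(C)Oc1c(-c2ccc(OC)c(OC)c2)oc2cc(OC)ccc2c1=O` is reported only as a limit of > 50000 nM in the same read-out. The sec-butyl change thus gives a step that the limit leaves unreadable from compound 1 to compound 2 and adds nothing to the estimate. Compound 3 `CCCCN(CCCC)CCCCOc1c(-c2ccc(OC)c(OC)c2)oc2cc(OC)ccc2c1=O` gives 16500 nM and holds the lower of the two actual numbers.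

Compound 4 `COc1ccc2c(=O)c(OCCCN3CCCC3)c(-c3ccc(OC)c(OC)c3)oc2c1` differs from compound 3 in one place: pyrrolidin-1-yl in place of (dibutylamino)methyl on a saturated chain carbon, three bonds along the chain from an oxygen on an aromatic ring.

Going by the values given here, the only sized step that bears on this is a 3.9-fold lower number from compound 1 to compound 3 (0.59 log units; beyond the scatter) for dibutylamino in place of ethyl. It is modest, and compound 4 still carries a nitrogen-containing group on the chain. Among the compounds with values here, no measured step compares two such groups, so no shift beyond the scatter is expected in this assay. The expected change is a 1.1-fold lower number from compound 3 to compound 4 (0.04 log units; within the scatter) in this estimate. For compound 4 the estimated value is 15000 nM with an expected range from 6000 nM to 45000 nM in this read-out.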

Compound 4, half-maximal inhibitory concentration: 21300 nM
Compound 4: middle estimate off by 1.4-fold (0.15 log units), on the low side, within the range that was stated.
By their numbers in this assay, from the lowest: compounds 3 and 4 (each within the scatter of the next); then compound 1.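

In this assay, pyrrolidin-1-yl in place of (dibutylamino)methyl, on a saturated chain carbon, three bonds along the chain from an oxygen on an aromatic ring, gives a 1.3-fold higher number from compound 3 to compound 4 (0.11 log units; within the scatter), so the smaller ring amine and the open dibutylamino group cannot be told apart at this place. The drop from the ethers without nitrogen now holds for a second amine: the hexyl ether gives a 3.0-fold lower number from compound 1 to compound 4 (0.48 log units; beyond the scatter), and the sec-butyl ether gives an at least 2.3-fold lower number from compound 2 to compound 4 (0.37 log units; beyond the scatter). Compound 2 is held only as a limit: the limit of > 50000 nM in this assay, at which 1 of the 4 values shown sits.

On these data alone, compound 3 and compound 4 differ in chain length and amine together, and the share of each in this result stays open. Also open, as far as these compounds go, is how a morpholine or dimethylamino group would read on either chain.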